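From 4-Fluorophenyl to Phenyl: What Compound 4 May Show

This account rests on a few compounds, and the source may have more. Where it says the series, first, only, none or still open, it means among the compounds named here.

Of the compounds shown here, three have been measured in a functional assay on M21 cells (Homo sapiens) for antiproliferative activity, read by sulforhodamine B assay, with a stated time of 48 h; a lower number here means a stronger inhibitor, a higher number a weaker inhibitor. Compound 1 `Cc1ccc(NS(=O)(=O)c2ccc(N3CCNC3=O)cc2)cc1` gives 260 nM, compound 2 `O=C1NCCN1c1ccc(S(=O)(=O)Nc2ccc(F)cc2)cc1` gives 230 nM, and compound 3 `CCCCc1ccc(NS(=O)(=O)c2ccc(N3CCNC3=O)cc2)cc1` gives 450 nM. Compound 2 thus sits within the scatter of both others, so these numbers do not separate it from them.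

Compound 4 `O=C1NCCN1c1ccc(S(=O)(=O)Nc2ccccc2)cc1` differs from compound 2 in a single place: hydrogen in place of fluoro on an aromatic carbon. This puts hydrogen in place of fluoro on an aromatic carbon, turning 4-fluorophenyl into phenyl.

Other groups at that same place have changed the number very little. Methyl to fluoro gave a 1.1-fold lower number from compound 1 to compound 2 (0.05 log units; within the scatter), fluoro to butyl gave a 2.0-fold higher number from compound 2 to compound 3 (0.29 log units; within the scatter), and methyl to butyl gave a 1.7-fold higher number from compound 1 to compound 3 (0.24 log units; within the scatter). For the measured compounds named here, none of the measured compounds carries hydrogen there, so this remains an extrapolation.

On these steps, no change beyond the scatter is expected. The expected step is a 1.2-fold higher number from compound 2 to compound 4 (0.09 log units; within the scatter). For compound 4 the estimate is 280 nM, with an expected range of 140 nM to 560 nM.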

Compound 4, half-maximal inhibitory concentration: 200 nM
Compound 4: middle estimate off by 1.4-fold (0.15 log units), on the high side; measured number inside the range.
By their numbers in this assay, from the lowest: compounds 4, 2, 1 and 3 (each within the scatter of the next, the first and the last beyond it).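

In this assay, the bare phenyl can now be compared directly with its substituted partners. The steps of a 1.2-fold lower number from compound 2 to compound 4 (0.06 log units; within the scatter) and a 1.3-fold lower number from compound 1 to compound 4 (0.11 log units; within the scatter) show that hydrogen cannot be told apart from fluoro or methyl at this position. For the compounds shown here, the step of a 2.3-fold lower number from compound 3 to compound 4 (0.35 log units; beyond the scatter) is the first at this position to pass the scatter, though only modestly, so butyl separates from hydrogen even though it stayed within the scatter of both fluoro and methyl.

As far as these compounds go, what an amine, a hydroxyl or a carboxylic acid would do on this aromatic carbon remains open, as does the effect of a chain longer than butyl. Nothing available gives a reason for any of these steps.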